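A few compounds are considered here, and "the series" means these few. Any claim that something is new, unique, unknown or untested is made for them only; others in the source may bear on it.

In an ADME assay on MDCK cells (Canis lupus familiaris) for cytotoxicity, read by microscopy, with a stated time of 6 days (on this read-out lower numbers stand for higher toxicity in this test and higher numbers for lower toxicity in this test), compound 3 `COCCN1C(N)=NC(N)=NC12CCN(C(=O)c1cccn1C)CC2` gives only a limit, > 100000 nM. Compound 1 `COc1cccc(N2C(N)=NC(N)=NC23CCN(C(=O)c2ccc(C(F)(F)F)cc2C)CC3)c1` likewise stops at a limit in this assay, > 100000 nM. Compound 2 `CCCN1C(N)=NC(N)=NC12CCN(S(=O)(=O)CCC)CC2` too is recorded only as a limit in this assay, > 100000 nM. So compound 3 stands where every value shown stands, namely at the limit of > 100000 nM in this assay, at which 3 of the 3 values shown sit, and no number separates it from the other two. Compound 4 `COCCN1C(N)=NC(N)=NC12CCN(C(=O)Nc1ccc(OC)cc1)CC2` differs from compound 3 in one place: (4-methoxyphenyl)amino in place of 1-methyl-1H-pyrrol-2-yl on a carbonyl carbon. Among the compounds with values here, no measured pair in this set carries a comparable change, so its size cannot be read from the data. Because compound 3 already sits at the limit > 100000 nM, the step of a number no higher from compound 3 to compound 4 (the limit leaves the size open) is expected to be none beyond the scatter. Compound 4 is therefore estimated at 100000 nM in this assay, within 40000 nM to 300000 nM, probably again reported only as a limit.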

Compound 4, minimum cytotoxic concentration: > 100000 nM
Compound 4: a limit, no number; the forecaster's own chance of this, stated with the estimate: 80%; the middle value sits exactly at the limit.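

No step can be read from compound 3 to compound 4, because both stop at a limit, not a number: the limit of > 100000 nM in this assay, at which 4 of the 4 values shown sit. The compounds shown leave open whether any structural change among them would give a measurable value in this assay.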